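Replacing a chloropyridinyl amide with a propylphenyl amide

A few compounds are considered here, and "the series" means these few. Any claim that something is new, unique, unknown or untested is made for them only; others in the source may bear on it.

Of the compounds shown here, three sharing one core have been measured in a functional assay on HepG2 cells (Homo sapiens) for antiproliferative activity, read by CCK-8 assay, with a stated time of 72 h; a higher number here means a weaker inhibitor, a lower number a stronger inhibitor. Compound 1 `O=C(Nc1cccc(-c2oc3cc(-c4ccc(F)cc4)ccc3c(=O)c2O)c1)c1ccc(F)cc1F` gives 26400 nM. Compound 2 `O=C(Nc1cccc(-c2oc3cc(-c4ccc(F)cc4)ccc3c(=O)c2O)c1)c1ccc(Br)cc1` gives 13900 nM. Compound 3 `O=C(Nc1cccc(-c2oc3cc(-c4ccc(F)cc4)ccc3c(=O)c2O)c1)c1ccc(Cl)nc1` gives 4610 nM, the lowest of the three numbers. The step of a 1.9-fold lower number from compound 1 to compound 2 (0.28 log units; within the scatter) lies within the scatter, while a 5.7-fold lower number from compound 1 to compound 3 (0.76 log units; beyond the scatter) and a 3.0-fold lower number from compound 2 to compound 3 (0.48 log units; beyond the scatter) are both beyond it, so the chloropyridinyl amide of compound 3 stands apart from the two carbocyclic amides.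

Compound 4 `CCCc1ccc(C(=O)Nc2cccc(-c3oc4cc(-c5ccc(F)cc5)ccc4c(=O)c3O)c2)cc1` differs from compound 3 in one place: 4-propylphenyl in place of 6-chloropyridin-3-yl on a carbonyl carbon. The change carries the amide substituent back to a six-membered ring of carbon only, which in compound 1 and compound 2 went with higher numbers than in compound 3. The two relevant steps, a 5.7-fold lower number from compound 1 to compound 3 (0.76 log units; beyond the scatter) and a 3.0-fold lower number from compound 2 to compound 3 (0.48 log units; beyond the scatter), were modest, and a step of similar size in the opposite direction is expected here, giving compound 4 an estimated 2.4-fold higher number from compound 3 to compound 4 (0.38 log units; beyond the scatter) in this assay. Compound 4 is therefore expected to read about 11000 nM, within a range from 4000 nM to 30000 nM.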

Compound 4, half-maximal inhibitory concentration: 51500 nM
Compound 4: middle estimate off by 4.7-fold (0.67 log units), on the low side; measured number above the stated range.
By their numbers in this assay, from the lowest: compound 3; then compounds 2, 1 and 4 (each within the scatter of the next, the first and the last beyond it).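

In this assay, within the data shown here, moving from the 6-chloropyridin-3-yl amide to the 4-propylphenyl amide is a large change (an 11-fold higher number from compound 3 to compound 4 (1.05 log units; beyond the scatter)), so this position responds more strongly than the earlier compounds showed. Propyl in place of bromo on the aromatic carbon also counts against compound 4 (a 3.7-fold higher number from compound 2 to compound 4 (0.57 log units; beyond the scatter)), whereas the comparison with the 2,4-difluorophenyl amide stays inside the scatter (a 2.0-fold higher number from compound 1 to compound 4 (0.29 log units; within the scatter)). Nothing measured here explains these differences. All three amides with a ring of carbon only read higher than compound 3, but the ring nitrogen and the chlorine of compound 3 change together, so their shares remain unresolved; a 4-chlorophenyl amide and a plain pyridin-3-yl amide would separate them. As far as these compounds go, how a methyl, a longer chain or an amine in place of propyl would read also remains open.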